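The compounds below may be only part of what the source reports. "The series", "measured", "known", "first", "only" and "open" are said of these compounds alone.

Of the compounds shown here, two have been measured in a toxicity assay on HepG2 cells (Homo sapiens) for inhibition, read by CellTiter-Glo, with a stated time of 48 h; on this read-out higher numbers stand for weaker inhibition and lower numbers for stronger inhibition. Compound 1 `COc1ccc2nc(C)cc(OCC(=O)Nc3cc(F)cc(F)c3)c2c1` gives > 100000 nM, which is a limit of the assay rather than a number. Compound 2 `COc1ccc2nc(C)cc(OCC(=O)Nc3ccc(Cl)cc3)c2c1` likewise gives > 100000 nM, again a limit. The step that the two limits leave unreadable from compound 1 to compound 2 stays unreadable because the limit of > 100000 nM in this assay, at which 2 of the 2 values shown sit, holds both values. Compound 2 thus stands at that limit, alongside compound 1, with no numeric potency in hand.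

Compound 3 `COc1ccc2nc(C)cc(OCC(=O)Nc3nccs3)c2c1` differs from compound 2 in one place: 1,3-thiazol-2-yl in place of 4-chlorophenyl on an amide-type nitrogen. Among the compounds with values here, the only measured step concerns a different exchange on the same amide-type nitrogen, and its size is not readable, so it offers no guide to direction or size for this change. Compound 3 is therefore expected to remain at the limit as well, the expected step that the limit leaves unreadable from compound 2 to compound 3 carrying no readable size. Compound 3 is estimated at 150000 nM, within a range from 50000 nM to 500000 nM.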

Compound 3, half-maximal inhibitory concentration: > 100000 nM
Compound 3: a limit, no number (the forecaster's own chance of this, stated with the estimate: 80%); the middle value does not contradict the limit.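

Compound 3 sits at the same limit as compound 1 and compound 2 in this assay, so the steps from compound 1 and compound 2 to compound 3 cannot be read: the limit of > 100000 nM in this assay, at which 3 of the 3 values shown sit. The compounds shown leave open whether any exchange on the amide-type nitrogen alters inhibition in this assay at all.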